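The source may report more compounds than this note shows. Statements on the series, on what has been measured and on what is new or still open speak of the compounds shown alone.

For the measured compounds named here, in a functional assay on MCF-10A cells (Homo sapiens) for antiproliferative activity, with a stated time of 48 h (a lower number here means that less compound is needed, a higher number that more compound is needed for the effect), compound 1 (`COc1ccc2nc(C)cc(NCc3ccccc3)c2c1`) gives 25900 nM, the highest number of the three measured so far. Compound 2 (`COc1ccc2nc(C)cc(NCc3ccc(C(C)(C)C)cc3)c2c1`) gives 6900 nM, and compound 3 (`COc1ccc2nc(C)cc(NCc3ccc(C(F)(F)F)cc3)c2c1`) gives 7600 nM. Compound 4 (`COc1ccc2nc(C)cc(NCc3ccccc3OC)c2c1`) keeps the structure of compound 1 except for one change, methoxy in place of hydrogen on an aromatic carbon, ortho to a large group.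

Going by the values given here, two measured steps bear on this change, since each also replaces a hydrogen on an aromatic carbon. With tert-butyl, the data show a 3.8-fold lower number from compound 1 to compound 2 (0.57 log units; beyond the scatter). With trifluoromethyl, they show a 3.4-fold lower number from compound 1 to compound 3 (0.53 log units; beyond the scatter). Both steps are modest and point the same way, and the two substituted compounds stay close together, with a 1.1-fold higher number from compound 2 to compound 3 (0.04 log units; within the scatter). Neither step introduces methoxy or places its group ortho to a large group, so the data do not test this change directly.

A modest lowering in this assay is therefore expected, probably smaller than the two measured steps, and a result within the scatter would not be surprising. The estimated step is a 1.9-fold lower number from compound 1 to compound 4 (0.27 log units; within the scatter). Compound 4 is expected at 14000 nM, with an estimated range from 6000 nM to 30000 nM.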

Compound 4, half-maximal effective concentration: 25200 nM
Beside the measured number, compound 4's estimate is 1.8-fold (0.26 log units) below it, and the stated range covers the measured number.
By their numbers in this assay, from the lowest: compounds 2 and 3 (each within the scatter of the next); then compounds 4 and 1 (each within the scatter of the next).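

In this assay, methoxy in place of hydrogen, ortho to a large group, gives a 1.0-fold lower number from compound 1 to compound 4 (0.01 log units; within the scatter), a step that stays within the scatter, unlike a 3.8-fold lower number from compound 1 to compound 2 (0.57 log units; beyond the scatter) with tert-butyl and a 3.4-fold lower number from compound 1 to compound 3 (0.53 log units; beyond the scatter) with trifluoromethyl. Filling a hydrogen position on this aromatic ring therefore does not lower the number in every case: the lowering holds for compound 2 and compound 3, and compound 4 goes against it. Nothing available on these compounds accounts for this difference between the steps.

The compounds shown do not separate the group from its place, so it remains open whether methoxy elsewhere on the ring would lower the number as tert-butyl and trifluoromethyl do, or whether either of those two groups, ortho to a large group, would keep its lowering. Also open, going by these compounds, is how a hydroxyl, an amine or a carboxylic acid ortho to a large group would compare with the hydrogen of compound 1.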